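Swapping a difluorophenyl for a bromo-methoxyphenyl ring

A few compounds are considered here, and "the series" means these few. Any claim that something is new, unique, unknown or untested is made for them only; others in the source may bear on it.

Three measured compounds share one core and differ only in the aromatic ring that sits on a saturated chain carbon bound to an aromatic carbon: compound 1 `Cc1c(Cc2cccc(F)c2)c(=O)oc2cc(OCC(O)CN3CCC(C(N)=O)CC3)ccc12`, compound 2 `Cc1c(Cc2ccc(Cl)cc2)c(=O)oc2cc(OCC(O)CN3CCC(C(N)=O)CC3)ccc12` and compound 3 `Cc1c(Cc2ccc(F)cc2F)c(=O)oc2cc(OCC(O)CN3CCC(C(N)=O)CC3)ccc12`. In an ADME assay on A549 cells (Homo sapiens) for cytotoxicity, read by CellTiter-Glo (on this read-out lower numbers stand for higher toxicity in this test and higher numbers for lower toxicity in this test), compound 1 gives 53300 nM. In this assay compound 2 gives 40000 nM. For compound 3, this assay reports only a limit, > 100000 nM. That is the limit of > 100000 nM in this assay, at which 1 of the 3 values shown sits. Comparing the three: a 1.3-fold lower number from compound 1 to compound 2 (0.12 log units; within the scatter); an at least 1.8-fold higher number from compound 1 to compound 3 (0.27 log units; that floor lies within the scatter); an at least 2.5-fold higher number from compound 2 to compound 3 (0.39 log units; beyond the scatter). Compound 3 therefore sits at the upper edge of the numbers shown, at a limit rather than a value, while compound 1 and compound 2 sit within the scatter of each other.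

Compound 4 `COc1ccc(Cc2c(C)c3ccc(OCC(O)CN4CCC(C(N)=O)CC4)cc3oc2=O)c(Br)c1` differs from compound 3 by 2-bromo-4-methoxyphenyl in place of 2,4-difluorophenyl on a saturated chain carbon bound to an aromatic carbon. Going by the values given here, none of the measured steps exchanges a fluorinated ring for a ring carrying bromine and methoxy, so they only loosely bear on this change; what they show is that swapping one small halogenated ring for another moved the read-out by little, and two of them stayed within the scatter. The step from compound 3 to compound 4 in this assay is therefore expected to be an at least 1.4-fold lower number from compound 3 to compound 4 (0.15 log units; that floor lies within the scatter), most likely a small drop back toward where compound 1 and compound 2 lie. The estimate for compound 4 is 70000 nM, with a range from 25000 nM to 200000 nM.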

Compound 4, half-maximal cytotoxic concentration: 44400 nM
Compound 4: middle estimate off by 1.6-fold (0.20 log units), on the high side, within the range that was stated.
By their numbers in this assay, from the lowest: compounds 2, 4 and 1 (each within the scatter of the next). At a limit, above all of these: compound 3.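

At this position, the 2-bromo-4-methoxyphenyl ring gives up the clear separation from the limit seen with the 2,4-difluorophenyl ring, and in this assay the change gives an at least 2.2-fold lower number from compound 3 to compound 4 (0.35 log units; beyond the scatter). The same ring does not separate from the two rings carrying a single halogen, with a 1.1-fold higher number from compound 2 to compound 4 (0.05 log units; within the scatter) and a 1.2-fold lower number from compound 1 to compound 4 (0.08 log units; within the scatter), so three differently substituted rings, including one that brings in bromine and a methoxy group, read alike here. Compound 3 is the only exception to that sameness, although its reading is a limit and not a number: the limit of > 100000 nM in this assay, at which 1 of the 4 values shown sits.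

The compounds shown leave open where compound 3 truly lies, and whether the bromine or the methoxy group matters more in the step from the 2,4-difluorophenyl ring, as the two arrive together in compound 4. Also open, on these data alone, is how this read-out would respond to a ring at the same place bearing an amine or a carboxylic acid, groups unlike any of the halogens or the methoxy group seen so far.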